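The compounds below may be only part of what the source reports. "The series", "measured", "known", "first", "only" and "open" are said of these compounds alone.

The account follows a single change made to compound 1, whose structure is `CC(C)n1cc(-c2ccnc3[nH]c(C4CCNCC4)cc23)ccc1=O`, in a physicochemical assay for solubility, in phosphate buffer, at pH 7.4; a higher number here means a more soluble compound, a lower number a less soluble compound. Compound 1 gives 910000 nM, the highest of the two plain numbers shown. Its nearest neighbour is compound 2, `CC(C)Cn1cc(-c2ccnc3[nH]c(C4CCN(CC(=O)N(C)C)CC4)cc23)ccc1=O`, which gives 390000 nM in this assay. Compound 3, `CCn1cc(-c2ccnc3[nH]c(C4CCN(CC(=O)N(C)C)CC4)cc23)ccc1=O`, reaches only a limit of this assay, reported as > 1000000 nM. Among the compounds with values here, the one step measured between neighbours, an at least 2.5-fold higher number from compound 2 to compound 3 (0.40 log units; beyond the scatter), shows that a smaller saturated group in place of a larger one raised the number by at least a modest amount, the limit of > 1000000 nM in this assay, at which 1 of the 3 values shown sits, marking the ceiling that compound 3 sits at.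

The new compound 4, `CC(C)n1cc(-c2ccnc3[nH]c(C4CCN(Cc5cccs5)CC4)cc23)ccc1=O`, differs from compound 1 by (thiophen-2-yl)methyl in place of hydrogen on an amine nitrogen in a ring. Within the data shown here, no measured step touches the amine nitrogen in the ring, so the expectation rests on direction alone: the measured step rewarded the smaller group, and here a larger group enters. Compound 4 is therefore expected to give a lower number than compound 1, an estimated 100000 nM, within 20000 nM to 400000 nM, a step of a 9.1-fold lower number from compound 1 to compound 4 (0.96 log units; beyond the scatter).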

Compound 4, solubility: 25000 nM
Compound 4: the middle estimate sits 4.0-fold (0.60 log units) above what was measured; the measured number falls inside the stated range.
By their numbers in this assay, from the lowest: compound 4; then compound 2; then compound 1. At a limit, above all of these: compound 3.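

In this assay, the amine nitrogen in the ring proves to be a place where one change alone has a large effect: (thiophen-2-yl)methyl in place of hydrogen gives a 36-fold lower number from compound 1 to compound 4 (1.56 log units; beyond the scatter) as a single step. Compound 2 and compound 3 also carry a group on that nitrogen, but each differs from compound 1 in a second place as well, so neither could isolate this position. Nothing measured here bears on the cause of the drop.

Going by these compounds, it remains open whether a plain methyl, a phenylmethyl group or a chain ending in a carboxylic acid on this nitrogen would lower the number as far. Also open, on these data alone, is whether the same change would have a step of similar size with an ethyl group on the aromatic nitrogen.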